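The source may hold more compounds than are shown below. What is called first, only, known or untested is meant among the compounds shown, and "the series" means these compounds.

Of the compounds shown here, three built on one shared core have so far been tested in an assay on C6 glioma cells for displacement of a labelled ligand from sodium- and chloride-dependent glycine transporter 1 (Rattus norvegicus), read by scintillation counting, with stated times of 30 min and 10 min; a lower number here means a stronger inhibitor, a higher number a weaker inhibitor. Compound 1 `CCc1nnc(-c2ccc(-c3ccccc3)cn2)n1-c1ccccc1F` gives 700 nM. Compound 2 `CCc1nnc(-c2ccc(-c3ccccc3)cc2)n1-c1ccccc1C` gives 300 nM, a smaller number than that of compound 1, and the gap between those two lies beyond the usual scatter. Within the data shown here, compound 3 `CCc1nnc(-c2ccc(-c3ccccc3)cc2)n1-c1cccc(CO)c1C` gives 250 nM; the step of a 1.2-fold lower number from compound 2 to compound 3 (0.08 log units; within the scatter) is the only single change recorded from compound 2, and it stays within the scatter, so the hydroxymethyl group made no reliable difference.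

Compound 4 `CCc1nnc(-c2ccc(-c3ccccc3)cc2)n1-c1cccc(F)c1C` has not yet been measured. It differs from compound 2 by fluoro in place of hydrogen on an aromatic carbon. Among the measured compounds shown here, no measured step puts a fluoro on that ring, so the one guide is the hydroxymethyl change on the same ring, which barely moved the number. On that basis the expected step is a 1.2-fold lower number from compound 2 to compound 4 (0.08 log units; within the scatter), nothing beyond the scatter. Compound 4 is therefore estimated at 250 nM, with a likely range from 100 nM to 600 nM.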

Compound 4, half-maximal inhibitory concentration: 630 nM
For compound 4 the middle estimate is 2.5-fold (0.40 log units) below the measured one, outside the stated range (above it).
By their numbers in this assay, from the lowest: compounds 3 and 2 (each within the scatter of the next); then compounds 4 and 1 (each within the scatter of the next).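

In this assay this carbon of the 2-methylphenyl ring proves sensitive to what is placed on it: fluoro ortho to a methyl group gives a 2.1-fold higher number from compound 2 to compound 4 (0.32 log units; beyond the scatter) and so weakens binding by more than the scatter, something the hydroxymethyl change had not shown. Replacing hydroxymethyl with fluoro at the same carbon gives a 2.5-fold higher number from compound 3 to compound 4 (0.40 log units; beyond the scatter) and this shows that the two groups do not act alike there, even though hydroxymethyl itself left the number within the scatter of hydrogen. Nothing available here explains this difference.

On these data alone, whether a chloro, a methoxy or an amine on this carbon would read like compound 3 or like compound 4 remains open. As far as these compounds go, it is also open whether fluoro on another carbon of this ring would cost as much.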